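The compounds below may be only part of what the source reports. "The series", "measured", "known", "first", "only" and "open" are said of these compounds alone.

Compound 1 `CC1(C)Oc2ccc(C(=O)c3ccccc3)cc2[C@@H](/N=C(\NC#N)Nc2ccc(Cl)cc2)[C@@H]1O` is the point of departure. In a functional assay (aorta) with Rattus norvegicus as the target (on this read-out higher numbers stand for weaker inhibition and lower numbers for stronger inhibition), compound 1 gives 7100 nM, the second highest of the three numbers at hand. Compound 2 `CC1(C)Oc2ccc(Cc3ccccc3)cc2[C@@H](/N=C(\NC#N)Nc2ccc(Cl)cc2)[C@@H]1O` gives 10000 nM in this assay, and the step of a 1.4-fold higher number from compound 1 to compound 2 (0.15 log units; within the scatter) stays within the scatter, so the two are not told apart. Compound 3 `CC1(C)Oc2ccc(S(=O)(=O)Nc3ccccc3)cc2[C@@H](/N=C(\NC#N)Nc2ccc(Cl)cc2)[C@@H]1O` gives 3300 nM in this assay, the lowest of the three numbers. Compound 4 `CC1CC(C)CN(S(=O)(=O)c2ccc3c(c2)[C@@H](/N=C(\NC#N)Nc2ccc(Cl)cc2)[C@H](O)C(C)(C)O3)C1` is not yet measured. It differs from compound 1 in one place: (3,5-dimethylpiperidin-1-yl)sulfonyl in place of benzoyl on an aromatic carbon. The measured steps that bear on this change are the two leading into compound 3, where a phenylsulfamoyl enters on an aromatic carbon: a 2.2-fold lower number from compound 1 to compound 3 (0.33 log units; beyond the scatter) and a 3.0-fold lower number from compound 2 to compound 3 (0.48 log units; beyond the scatter), both modest, both beyond the scatter, both toward lower numbers. The group entering compound 4 likewise carries a sulfonyl on that aromatic carbon, so a modest step toward lower numbers is expected. On that basis compound 4 is expected to show a 2.0-fold lower number from compound 1 to compound 4 (0.31 log units; beyond the scatter) in this assay. Compound 4 is therefore estimated at 3500 nM in this assay, with a range from 1500 nM to 8000 nM.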

Compound 4, half-maximal inhibitory concentration: 32100 nM
Estimate against measurement, compound 4: 9.2-fold (0.96 log units) below, outside the stated range (above it).
By their numbers in this assay, from the lowest: compound 3; then compounds 1 and 2 (each within the scatter of the next); then compound 4.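

The sulfonyl on this aromatic carbon does not by itself set the direction in this assay: 3,5-dimethylpiperidin-1-yl in place of anilino on the sulfonyl sulfur gives a 9.7-fold higher number from compound 3 to compound 4 (0.99 log units; beyond the scatter). What stands on that sulfur therefore decides the outcome, since the (3,5-dimethylpiperidin-1-yl)sulfonyl group gives a 4.5-fold higher number from compound 1 to compound 4 (0.66 log units; beyond the scatter) and also a 3.2-fold higher number from compound 2 to compound 4 (0.51 log units; beyond the scatter), the opposite direction to the steps into the phenylsulfamoyl group. Nothing at hand explains this reversal.

The compounds shown leave open whether the two methyl groups on the piperidine ring matter, which piperidin-1-ylsulfonyl without them would test. They also leave open where a morpholin-4-ylsulfonyl or an N-methylphenylsulfamoyl group on this carbon would fall.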